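This account rests on a few compounds, and the source may have more. Where it says the series, first, only, none or still open, it means among the compounds named here.

In a functional assay on BXPC-3 cells (Homo sapiens) for inhibition, read by XTT assay, with a stated time of 72 h (a higher number here means a weaker inhibitor, a lower number a stronger inhibitor), compound 2 `CC(=O)N1CCC[C@H]1COCCCCCCCCC/C=C/c1ccc(-c2ccccc2)cc1` gives 56700 nM and compound 1 `O=CN1CCC[C@H]1COCCCCCCCCC/C=C/c1ccc(Oc2ccccc2)cc1` gives 65000 nM so the two stand within the scatter of each other. Compound 3 `CC(=O)N1CCC[C@H]1COCCCCCCCCC/C=C/c1ccc(Oc2ccccc2)cc1` departs from compound 2 by phenoxy in place of phenyl on an aromatic carbon in one place: phenoxy in place of phenyl on an aromatic carbon. Compound 1 also carries phenoxy and its 65000 nM lies within the scatter of the value of compound 2, so no step beyond the scatter is expected in this assay in either direction. The estimated change is a 1.0-fold higher number from compound 2 to compound 3 (0.01 log units; within the scatter) and no larger. Compound 3 is estimated at 58000 nM with an expected range from 29000 nM to 110000 nM in this read-out.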

Compound 3, half-maximal inhibitory concentration: 73300 nM
Compound 3: middle estimate off by 1.3-fold (0.10 log units), on the low side; the measured number falls inside the stated range.
By their numbers in this assay, from the lowest: compounds 2, 1 and 3 (each within the scatter of the next).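

With the carbonyl substituent held constant, phenoxy in place of phenyl on an aromatic carbon, para to a large group, gives a 1.3-fold higher number from compound 2 to compound 3 (0.11 log units; within the scatter) in this assay and so does not separate the pair. With phenoxy held constant, methyl in place of hydrogen on a carbonyl carbon gives a 1.1-fold higher number from compound 1 to compound 3 (0.05 log units; within the scatter) in the same read-out, so this second change does not separate its pair either. Nothing at hand speaks to why either change leaves the number within the scatter.

Going by these compounds, whether an amine or a carboxylic acid in place of phenoxy would give a step beyond the scatter remains open. The same holds for a shorter chain in the shared core.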